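A few compounds are considered here, and "the series" means these few. Any claim that something is new, unique, unknown or untested is made for them only; others in the source may bear on it.

In a functional assay on B16 cells (Mus musculus) for cytotoxicity, read by CCK-8 assay, with a stated time of 24 h (a higher number here means a weaker inhibitor, a lower number a stronger inhibitor), compound 1 (`COc1ccccc1Oc1c(N)nc(-c2ccc(C)cc2)nc1Cl`) gives 17400 nM and compound 2 (`COc1cccc(-c2nc(N)c(Oc3ccccc3OC)c(Cl)n2)c1`) gives 23600 nM while compound 3 (`COc1ccccc1Oc1c(N)nc(-c2ccccc2F)nc1Cl`) gives 13800 nM so compound 2 stands within the scatter of both others. Compound 4 (`COc1cccc(-c2nc(N)c(Oc3ccccc3OC)c(OCCO)n2)c1`) carries 2-hydroxyethoxy in place of chloro on an aromatic carbon of compound 2 (2-hydroxyethoxy in place of chloro on an aromatic carbon). Among the measured compounds shown here, the steps of a 1.4-fold higher number from compound 1 to compound 2 (0.13 log units; within the scatter) and a 1.3-fold lower number from compound 1 to compound 3 (0.10 log units; within the scatter) and a 1.7-fold lower number from compound 2 to compound 3 (0.23 log units; within the scatter) all lie within the scatter, but each only exchanges one substituted phenyl group for another, and no measured compound replaces the chloro. They give no direct size for this change, so no step beyond the scatter is expected, with wide uncertainty. An estimated 1.2-fold higher number from compound 2 to compound 4 (0.07 log units; within the scatter) is expected on this basis. In this assay compound 4 is expected at 28000 nM (estimated range 10000 nM to 80000 nM).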

Compound 4, half-maximal inhibitory concentration: 30500 nM
For compound 4 the middle estimate is 1.1-fold (0.04 log units) below the measured one; measured number inside the range.
By their numbers in this assay, from the lowest: compounds 3, 1, 2 and 4 (each within the scatter of the next, the first and the last beyond it).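

In this assay, among the compounds shown here, the first change at the carbon next to the ring nitrogen, 2-hydroxyethoxy in place of chloro, gives a 1.3-fold higher number from compound 2 to compound 4 (0.11 log units; within the scatter). The earlier compounds shown here all kept the chloro and varied only the phenyl group, whereas this step shows that, with 3-methoxyphenyl in place, a larger group carrying a hydrogen-bond donor leaves the number within the scatter. Nothing available explains this result.

On these data alone, whether the same exchange holds with 4-methylphenyl or 2-fluorophenyl remains open. So does the effect of an amine, a carboxylic acid or a longer chain at this carbon.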